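The source may hold more compounds than are shown below. What is called first, only, known or untested is meant among the compounds shown, and "the series" means these compounds.

Two compounds have been tested in an in vitro functional assay on HEK285-7 cells for antagonist activity at prostaglandin D2 receptor 2 (Homo sapiens), read by BRET and beta-arrestin recruitment; on this read-out lower numbers stand for stronger inhibition and higher numbers for weaker inhibition:
compound 1, `O=C(O)Cc1sc(C(c2ccccc2)c2ccccc2)nc1-c1ccc(F)c(F)c1`, gives 43 nM
compound 2, `N#Cc1cc(-c2nc(C(c3ccc(F)cc3)c3ccc(F)cc3)sc2CC(=O)O)ccc1F`, gives 520 nM

Compound 2 has the higher of these two numbers, and compound 1 lies well below it, a gap beyond the usual scatter of this assay. For the measured compounds named here, since the two compounds differ in more than one place, no single step can be drawn between them. Compound 3, `CN(C)c1cc(-c2nc(C(c3ccc(F)cc3)c3ccc(F)cc3)sc2CC(=O)O)ccn1`, has not yet been measured. It arises from compound 2 by one change: 2-(dimethylamino)pyridin-4-yl in place of 3-cyano-4-fluorophenyl on an aromatic carbon. Going by the values given here, nothing measured so far shows how this assay responds to such an exchange, so the expectation rests on compound 2 alone. The step expected in this assay, a 1.3-fold higher number from compound 2 to compound 3 (0.13 log units; within the scatter), is a modest weakening, though a result within the scatter would not be surprising. Compound 3 is expected to give about 700 nM, with a likely range from 150 nM to 3000 nM.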

Compound 3, half-maximal inhibitory concentration: > 100000 nM
Compound 3 ended at the assay's limit (the forecaster's own chance of this, stated with the estimate: 10%); middle value at least 140-fold (2.15 log units) away from the limit.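

Replacing 3-cyano-4-fluorophenyl with 2-(dimethylamino)pyridin-4-yl on this aromatic carbon of the shared core gives an at least 190-fold higher number from compound 2 to compound 3 (2.28 log units; beyond the scatter) in this assay, so this position is far from indifferent to the group it carries. Compound 3 sits at a limit of the assay, so its figure is not an exact number: the limit of > 100000 nM in this assay, at which 1 of the 3 values shown sits. The two groups have the same number of heavy atoms and each has one six-membered aromatic ring, so a very large step here can occur with neither of those counts changing.

The compounds shown cannot separate the contribution of the pyridine ring nitrogen from that of the dimethylamino group. A plain pyridin-4-yl group and a dimethylaminophenyl group at this position would each carry only one of these two features, and so could tell them apart.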